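Swapping the aryl ether for a ring-linked pyridinone

The source may report more compounds than this note shows. Statements on the series, on what has been measured and on what is new or still open speak of the compounds shown alone.

Three compounds share one core, differing only in the group on the aromatic carbon ortho to the methylsulfonyl group. Compound 1 `Cc1cc(Sc2ccccc2Cl)c(S(C)(=O)=O)cc1C(=O)N=C(N)N` gives 14 nM in a functional assay for inhibition of sodium/hydrogen exchanger (Oryctolagus cuniculus); on this read-out lower numbers stand for stronger inhibition and higher numbers for weaker inhibition. Compound 2 `Cc1cc(OCc2ccccc2)c(S(C)(=O)=O)cc1C(=O)N=C(N)N` gives 28 nM. Compound 3 `Cc1cc(Oc2ccc(Cl)cc2)c(S(C)(=O)=O)cc1C(=O)N=C(N)N` gives 13 nM; it sits at the low end of the three numbers, indistinguishable from compound 1 with a 1.1-fold lower number from compound 1 to compound 3 (0.03 log units; within the scatter) and separated from compound 2 by a 2.2-fold lower number from compound 2 to compound 3 (0.33 log units; beyond the scatter).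

Compound 4 `Cc1cc(-n2ccc(=O)cc2)c(S(C)(=O)=O)cc1C(=O)N=C(N)N` differs from compound 3 by a group of 7 heavy atoms (5 carbon, 1 nitrogen, 1 oxygen; one six-membered aromatic ring with 1 hetero atom) in place of a group of 8 heavy atoms (6 carbon, 1 oxygen, 1 chlorine; one six-membered aromatic ring of carbon only), on an aromatic carbon. The group entering has no common name. Among the compounds with values here, no measured step exchanges a carbon-only ring for a ring with a hetero atom here; the nearest guides are the steps among compounds 1, 2 and 3, where changing the side group moved the number by at most a 2.0-fold higher number from compound 1 to compound 2 (0.30 log units; within the scatter). On that basis only a small shift is expected, with the loss of the chlorine and the new ring type adding uncertainty. Compound 4 is estimated at 40 nM, between 12 nM and 130 nM, which is expected to mean a 3.1-fold higher number from compound 3 to compound 4 (0.49 log units; beyond the scatter).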

Compound 4, half-maximal inhibitory concentration: 75 nM
Compound 4: the middle estimate sits 1.9-fold (0.27 log units) below what was measured; the range from low to high includes it.
By their numbers in this assay, from the lowest: compounds 3, 1 and 2 (each within the scatter of the next, the first and the last beyond it); then compound 4.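

No earlier change on this aromatic carbon moved the number as far: in this assay the new group gives a 5.8-fold higher number from compound 3 to compound 4 (0.76 log units; beyond the scatter) and a 5.4-fold higher number from compound 1 to compound 4 (0.73 log units; beyond the scatter), so this position does distinguish between side groups, and a ring with a hetero atom is not simply interchangeable with a carbon-only ring. Compound 2 carries no chlorine either, yet the change still gives a 2.7-fold higher number from compound 2 to compound 4 (0.43 log units; beyond the scatter), so the missing chlorine cannot be the whole difference. No measurement is available here that explains the loss.

On these data alone, whether a chlorine on the new ring would bring the number back remains open. Also open, as far as these compounds go, is how much of a ring this carbon needs at all, since a plain amine or a methoxy group there would test that directly.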